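Small Steps Around Compound 3, Then a New Group

A few compounds are considered here, and "the series" means these few. Any claim that something is new, unique, unknown or untested is made for them only; others in the source may bear on it.

In an ADME assay on cells (Peritoneal macrophage, Mus musculus, strain Balb/c) for cytotoxicity, read by resazurin assay, with a stated time of 72 h (on this read-out lower numbers stand for higher toxicity in this test and higher numbers for lower toxicity in this test), three relatives sharing one core have been measured. Compound 1 (`CC1(Cc2cccc(C(F)(F)F)c2)CC(S(=O)(=O)c2ccc(F)cc2)=C(c2ccc(/C(N)=N/O)cc2)O1`) gives 49800 nM and compound 2 (`CC1(Cc2ccccc2C(F)(F)F)CC(S(=O)(=O)c2ccc(F)cc2)=C(c2ccc(/C(N)=N/O)cc2)O1`) gives 105000 nM while compound 3 (`Cc1cccc(CC2(C)CC(S(=O)(=O)c3ccc(F)cc3)=C(c3ccc(/C(N)=N/O)cc3)O2)c1`) gives 112000 nM on this scale. Compound 3 shares the top of this small set with one neighbour, as a 1.1-fold higher number from compound 2 to compound 3 (0.03 log units; within the scatter) shows, and the remaining compound lies lower, as a 2.2-fold higher number from compound 1 to compound 3 (0.35 log units; beyond the scatter) shows.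

The change to compound 4 (`CC1(Cc2ccc(CO)cc2)CC(S(=O)(=O)c2ccc(F)cc2)=C(c2ccc(/C(N)=N/O)cc2)O1`) is 4-(hydroxymethyl)phenyl in place of 3-methylphenyl (4-(hydroxymethyl)phenyl in place of 3-methylphenyl on a saturated chain carbon bound to a saturated ring carbon) on a saturated chain carbon bound to a saturated ring carbon. For the measured compounds named here, no measured compound carries the new group, so the earlier steps guide size only and give no direction. Changes to this group have stayed modest, as a 2.1-fold higher number from compound 1 to compound 2 (0.32 log units; beyond the scatter) shows, and the same is true of the step to compound 3 above. The step expected in this assay is therefore a 1.1-fold higher number from compound 3 to compound 4 (0.03 log units; within the scatter) and thus none beyond the scatter. For compound 4 the expected value is 120000 nM with an estimated range from 55000 nM to 250000 nM around it.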

Compound 4, half-maximal cytotoxic concentration: > 100000 nM
Compound 4 gave a limit, no number; the forecaster's own chance of this, stated with the estimate: 20%; the middle value is on the limit's open side.
By their numbers in this assay, from the lowest: compound 1; then compounds 2 and 3 (each within the scatter of the next).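

In this assay compound 4 gives > 100000 nM, which is a limit of the assay and not a number. Measured against the 3-(trifluoromethyl)phenyl group, the new group gives an at least 2.0-fold higher number from compound 1 to compound 4 (0.30 log units; that floor lies within the scatter), so the result points towards lower toxicity in this test, but this floor alone does not separate the two compounds. The steps from compound 2 and compound 3 cannot be read, so this position is shown only to carry 4-(hydroxymethyl)phenyl without the reading falling under the limit, and the comparison stops there: the limit of > 100000 nM in this assay, at which 1 of the 4 values shown sits.

Going by these compounds, how far compound 4 lies past its limit stays unknown, so it cannot be said whether 4-(hydroxymethyl)phenyl truly differs from 3-methylphenyl. Also open, on these data alone, is how an amine or a carboxylic acid in place of the hydroxymethyl group would read in this assay.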